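From compound 3 to compound 4: a ringless side group

The source may report more compounds than this note shows. Statements on the series, on what has been measured and on what is new or still open speak of the compounds shown alone.

In an ADME assay on Vero cells (Chlorocebus sabaeus) for cytotoxicity, read by MTT assay, with a stated time of 72 h (on this read-out higher numbers stand for lower toxicity in this test and lower numbers for higher toxicity in this test), compound 1 `COc1c(N2CCN(CCC#N)C(C)C2)c(F)cc2c(=O)c(C(=O)O)cn(C3CC3)c12` gives 500 ug/mL, compound 2 `CO/N=C(\C)CN1CCN(c2c(F)cc3c(=O)c(C(=O)O)cn(C4CC4)c3c2OC)CC1C` gives 49.6 ug/mL, and compound 3 `COc1c(N2CCN(C/C(C)=N/Nc3ccccc3)C(C)C2)c(F)cc2c(=O)c(C(=O)O)cn(C3CC3)c12` gives 11.1 ug/mL, the lowest of the three numbers. Compound 4 `CCO/N=C(\C)CCN1CCN(c2c(F)cc3c(=O)c(C(=O)O)cn(C4CC4)c3c2OC)CC1C` has not been measured. It differs from compound 3 by a group of 7 heavy atoms (5 carbon, 1 nitrogen, 1 oxygen; no ring) in place of a group of 10 heavy atoms (8 carbon, 2 nitrogen; one six-membered aromatic ring of carbon only), on a saturated chain carbon bound to an amine nitrogen in a ring. The closest guide is a 4.5-fold lower number from compound 2 to compound 3 (0.65 log units; beyond the scatter), with anilino in place of methoxy on a double-bonded nitrogen. Compound 4, like compound 2, has no ring in this group. The larger steps, a 10-fold lower number from compound 1 to compound 2 (1.00 log units; beyond the scatter) and a 45-fold lower number from compound 1 to compound 3 (1.65 log units; beyond the scatter), show how far changes here can move the number. The expected step, a modest rise, is a 3.2-fold higher number from compound 3 to compound 4 (0.50 log units; beyond the scatter). The estimated value for compound 4 is 35 ug/mL, with an expected range from 12 ug/mL to 110 ug/mL.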

Compound 4, half-maximal cytotoxic concentration: 88.4 ug/mL
The estimate for compound 4 lay 2.5-fold (0.40 log units) below the measured number, and the stated range covers the measured number.
By their numbers in this assay, from the lowest: compound 3; then compounds 2 and 4 (each within the scatter of the next); then compound 1.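

In this assay, a ringless group in place of the group with the six-membered aromatic ring gives an 8.0-fold higher number from compound 3 to compound 4 (0.90 log units; beyond the scatter), so a higher number here does not depend on the exact ringless group. Two ringless groups that both carry oxygen are separated by only a 1.8-fold higher number from compound 2 to compound 4 (0.25 log units; within the scatter), whereas the nitrile-bearing group remains distinct, with a 5.7-fold lower number from compound 1 to compound 4 (0.75 log units; beyond the scatter). No supporting evidence is available to explain these differences. Going by these compounds, it remains open whether an amine or a carboxylic acid on this chain would give a number closer to that of compound 1 or compound 4.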